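A few compounds are considered here, and "the series" means these few. Any claim that something is new, unique, unknown or untested is made for them only; others in the source may bear on it.

Measured compounds in this series:

Compound 1, `Oc1ccc2c(O)cc(-c3ccccc3)nc2c1`: 0.55 ug/mL
Compound 2, `Oc1cc(-c2ccccc2)nc2cc(F)ccc12`: < 0.1 ug/mL
Compound 3, `Oc1cc(-c2ccccc2)nc2c(O)cccc12`: > 10 ug/mL

The read-out throughout is a functional assay on KB cells (Homo sapiens) for cytotoxicity; on this read-out higher numbers stand for an effect only at larger amounts of compound and lower numbers for an effect already at smaller amounts. Compound 1 gives 0.55 ug/mL. For compound 2 the result is only a limit of the assay, < 0.1 ug/mL. For compound 3 the result is likewise only a limit, > 10 ug/mL.

The change from compound 1 to compound 2 is fluoro in place of hydroxy on an aromatic carbon. Its step in this assay is an at least 5.5-fold lower number from compound 1 to compound 2 (0.74 log units; beyond the scatter); it is given as an at-least figure because the limit of < 0.1 ug/mL in this assay, at which 1 of the 3 values shown sits, applies to compound 2.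

Compound 3 shares the atoms of compound 1, joined differently; the difference between the two cores is not broken down here. Compound 4, `Oc1cc(-c2ccccc2)nc2c(F)cccc12`, is not yet measured. The change from compound 3 to compound 4 is fluoro in place of hydroxy on an aromatic carbon. It is the same kind of change as that from compound 1 to compound 2, but not the same: in compound 1 the place is meta to a fused ring and para to a fused ring, whereas in compound 3 it is ortho to a fused ring and meta to a fused ring.

Because the limit of > 10 ug/mL in this assay, at which 1 of the 3 values shown sits, applies to compound 3, the starting point for compound 4 is not a number, so the step of an at least 5.5-fold lower number from compound 1 to compound 2 (0.74 log units; beyond the scatter) cannot be carried over directly. Compound 4 is expected to give a step of an at least 3.3-fold lower number from compound 3 to compound 4 (0.52 log units; beyond the scatter) in this assay, a guess resting on the measured step alone. The estimate for compound 4 in this assay is therefore 3 ug/mL, within 0.5 ug/mL to 15 ug/mL.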

Compound 4, half-maximal effective concentration: 0.53 ug/mL
Estimate against measurement, compound 4: 5.7-fold (0.75 log units) above; the range from low to high includes it.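

In this assay the new step is an at least 18-fold lower number from compound 3 to compound 4 (1.27 log units; beyond the scatter), and it runs in the same direction as the earlier step on the core of compound 1, so fluoro in place of hydroxy on an aromatic carbon gives a lower number on both cores shown. The direction of the change therefore carries from one core to the other in this pair of examples, but nothing can be said about whether its size carries as well: the same change on two cores in this assay, an at least 5.5-fold lower number (0.74 log units; beyond the scatter) from compound 1 to compound 2 and an at least 18-fold lower number (1.27 log units; beyond the scatter) from compound 3 to compound 4; the limit leaves it open whether they differ Each step has a limit of the assay at one end and is not a full measure of the change, and two cores with the group at two different places on the ring make no rule for the wider series.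

The compounds shown leave open how other groups would read at these places, for instance chloro, methoxy or an amine, as only hydroxy and fluoro appear there. Also open, going by these compounds, is what the change does at other places on the same six-membered aromatic ring, and whether a pair with numbers at both ends would show the same direction.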